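Heptyl to 4-isopropylphenyl on the ether carbon of the series

The source may hold more compounds than are shown below. What is called first, only, known or untested is meant among the compounds shown, and "the series" means these compounds.

Three compounds sharing one core have numbers in a functional assay on HEK293 cells for agonist activity at G-protein coupled receptor 39 (Homo sapiens), read by scintillation proximity assay and inositol phosphate accumulation, with a stated time of 75 min; a lower number here means that less compound is needed, a higher number that more compound is needed for the effect. Compound 1 `Cc1nn(-c2ncnc3nc[nH]c23)c2c1C(OCC(=O)c1ccc(F)cc1)CC(=O)N2` gives 973 nM; compound 2 `Cc1nn(-c2ncnc3nc[nH]c23)c2c1C(OCc1ccc(Cl)cc1Cl)CC(=O)N2` gives 243 nM; compound 3 `CCCCCCCCOC1CC(=O)Nc2c1c(C)nn2-c1ncnc2nc[nH]c12` gives 388 nM, the second highest of the three. The steps of a 4.0-fold lower number from compound 1 to compound 2 (0.60 log units; beyond the scatter) and a 2.5-fold lower number from compound 1 to compound 3 (0.40 log units; beyond the scatter) are both modest, while a 1.6-fold higher number from compound 2 to compound 3 (0.20 log units; within the scatter) stays within the scatter. Compound 4 `Cc1nn(-c2ncnc3nc[nH]c23)c2c1C(OCc1ccc(C(C)C)cc1)CC(=O)N2` differs from compound 3 by 4-isopropylphenyl in place of heptyl on a saturated chain carbon bound to an oxygen on a saturated carbon. Among the compounds with values here, the only step bearing on an aromatic group in place of heptyl at this position is a 1.6-fold higher number from compound 2 to compound 3 (0.20 log units; within the scatter), which was within the scatter, so no change beyond the scatter is expected in this assay. The expected step is a 1.3-fold lower number from compound 3 to compound 4 (0.11 log units; within the scatter), and compound 4 is estimated at 300 nM with a range from 110 nM to 800 nM.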

Compound 4, half-maximal effective concentration: 1690 nM
For compound 4 the middle estimate is 5.6-fold (0.75 log units) below the measured one; measured number outside the range, above it.
By their numbers in this assay, from the lowest: compounds 2 and 3 (each within the scatter of the next); then compounds 1 and 4 (each within the scatter of the next).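

In this assay, an aromatic group on this saturated chain carbon does not always read like heptyl: a 4.4-fold higher number from compound 3 to compound 4 (0.64 log units; beyond the scatter) is beyond the scatter, unlike the earlier 2,4-dichlorophenyl comparison. The aromatic groups also separate from one another, with a 7.0-fold higher number from compound 2 to compound 4 (0.84 log units; beyond the scatter) beyond the scatter, while a 1.7-fold higher number from compound 1 to compound 4 (0.24 log units; within the scatter) stays within it. No measurement on hand accounts for these steps.

Still open, going by these compounds, is how a plain phenyl or a 4-chlorophenyl would read here, which would help separate the effect of the isopropyl group from that of the two chlorines. An amine or carboxylic acid at the end of the chain also remains untested among the compounds shown.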